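The source may report more compounds than this note shows. Statements on the series, on what has been measured and on what is new or still open speak of the compounds shown alone.

The question in an ADME assay on BJ cells (Homo sapiens), read by MTT assay, with a stated time of 72 h (on this read-out higher numbers stand for weaker inhibition and lower numbers for stronger inhibition), is how far the ribose-bearing core tolerates changes at its aryl position. Compound 1 `Nc1nc(N)c2c(-c3cc4ccccc4o3)cn([C@@H]3O[C@H](CO)[C@@H](O)[C@H]3O)c2n1` gives only a limit of the assay, > 100000 nM. Compound 2 `Cc1nc(N)c2c(-c3cc4ccccc4o3)cn([C@@H]3O[C@H](CO)[C@@H](O)[C@H]3O)c2n1` likewise gives only a limit, > 100000 nM. Compound 3 `Nc1nc(N)c2c(-c3ccccc3)cn([C@@H]3O[C@H](CO)[C@@H](O)[C@H]3O)c2n1` also reaches only a limit, > 100000 nM. Compound 2 thus stands where every value shown stands, at the limit of > 100000 nM in this assay, at which 3 of the 3 values shown sit. Compound 4 `Cc1nc(N)c2c(-c3cccs3)cn([C@@H]3O[C@H](CO)[C@@H](O)[C@H]3O)c2n1` is not yet measured; it differs from compound 2 by thiophen-2-yl in place of 1-benzofuran-2-yl on an aromatic carbon. The measured steps a step that the two limits leave unreadable from compound 1 to compound 2 and a step that the two limits leave unreadable from compound 1 to compound 3 touch the same position, but their sizes cannot be read. Because the values shown all sit at the limit of > 100000 nM in this assay, at which 3 of the 3 values shown sit, compound 4 is expected to show no step beyond the scatter, a number no higher from compound 2 to compound 4 (the limit leaves the size open). Compound 4 is therefore estimated at 100000 nM, between 40000 nM and 300000 nM, most likely again reported as a limit.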

Compound 4, half-maximal inhibitory concentration: > 100000 nM
Compound 4: only a limit was reported; the forecaster's own chance of this, stated with the estimate: 85%; the middle value lies on the limit itself.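

Compound 2 and compound 4 both give only a limit, so the step between them cannot be read. The compounds shown leave open how thiophen-2-yl and 1-benzofuran-2-yl compare in this assay, where every value shown is a limit.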